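Benzyl on the Aromatic Nitrogen of Compound 2

The source may hold more compounds than are shown below. What is called first, only, known or untested is meant among the compounds shown, and "the series" means these compounds.

In a functional assay on Bel-7402 cells (Homo sapiens) for antiproliferative activity, read by MTT assay, with a stated time of 72 h (a higher number here means a weaker inhibitor, a lower number a stronger inhibitor), compound 2 (`C=C1C(=O)O[C@H]2[C@H]1CC/C(COC(=O)CCC(=O)NCCCCCCNC(=O)Cn1cc(F)c(=O)[nH]c1=O)=C\CC[C@@]1(C)O[C@@H]21`) gives > 20000 nM, a limit and not a number. Compound 1 (`C=C1C(=O)O[C@H]2[C@H]1CC/C(COC(=O)Cn1cc(F)c(=O)[nH]c1=O)=C\CC[C@@]1(C)O[C@@H]21`) gives > 20000 nM, also a limit. Compound 2 thus stands at the limit of > 20000 nM in this assay, at which 2 of the 3 values shown sit.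

Compound 4 (`C=C1C(=O)O[C@H]2[C@H]1CC/C(COC(=O)CCC(=O)NCCCCCCNC(=O)Cn1cc(F)c(=O)n(Cc3ccccc3)c1=O)=C\CC[C@@]1(C)O[C@@H]21`) differs from compound 2 by benzyl in place of hydrogen on an aromatic nitrogen.

Going by the values given here, one measured step bears on this change. Compound 3 (`C=C1C(=O)O[C@H]2[C@H]1CC/C(COC(=O)Cn1cc(F)c(=O)n(Cc3ccccc3)c1=O)=C\CC[C@@]1(C)O[C@@H]21`), which carries the same benzyl, gives 3980 nM. That exchange produced an at least 5.0-fold lower number from compound 1 to compound 3 (0.70 log units; beyond the scatter), which lies beyond the scatter.

A similar move toward a lower number is therefore expected, with the estimated change in this assay being an at least 4.4-fold lower number from compound 2 to compound 4 (0.64 log units; beyond the scatter).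

For compound 4 the estimate is 4500 nM, with an expected range from 1300 nM to 18000 nM.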

Compound 4, half-maximal inhibitory concentration: 18300 nM
For compound 4 the middle estimate is 4.1-fold (0.61 log units) below the measured one; measured number outside the range, above it.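

With the chain of compound 2 in place, benzyl on the aromatic nitrogen gives a measured value in this assay, but the step can be read only as an at least 1.0-fold lower number from compound 2 to compound 4 (0.03 log units; that floor lies within the scatter). Going by these compounds, for compound 2, > 20000 nM is a limit and not a number, so the true size of the step stays unknown. The change can therefore be compared across the two cores only loosely: the same change on two cores in this assay, an at least 5.0-fold lower number (0.70 log units; beyond the scatter) from compound 1 to compound 3 and an at least 1.0-fold lower number (0.03 log units; that floor lies within the scatter) from compound 2 to compound 4; the limit leaves it open whether they differ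

The compounds shown leave open how a methyl or a phenethyl group on this nitrogen would compare with benzyl. They also leave open whether a shorter chain on the core of compound 4 would change the value.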